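The source may hold more compounds than are shown below. What is called first, only, known or untested is meant among the compounds shown, and "the series" means these compounds.

Working notes on the series. Compound 1 `CNC(=O)c1nc(-c2cc(OC)c(OC)c(OC)c2)n(-c2ccc(OC)cc2)n1`, compound 2 `COc1ccc(NC(=O)c2nc(-c3cc(OC)c(OC)c(OC)c3)n(-c3ccc(OC)cc3)n2)cc1` and compound 3 `COc1ccc(-n2nc(C(=O)Nc3ccccc3C)nc2-c2cc(OC)c(OC)c(OC)c2)cc1` share one core and differ only in the group on the amide-type nitrogen. In a functional assay on the whole organism for inhibition, with Rattus norvegicus as the target, read by paw edema, with stated times of 30 min and 3 h, at a dose of 0.28 mmol/kg by the oral route (on this read-out higher numbers stand for more inhibition at the one dose given (going by the name of the read-out) and lower numbers for less inhibition), compound 1 gives 109%, compound 2 gives 99% and compound 3 gives 74%. The steps read a number 10 percentage points lower from compound 1 to compound 2 (within the scatter), a number 35 percentage points lower from compound 1 to compound 3 (beyond the scatter) and a number 25 percentage points lower from compound 2 to compound 3 (beyond the scatter); compound 3 thus stands lowest of the three, and both steps leading to it lie beyond the scatter.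

Compound 4 `COc1ccc(-n2nc(C(=O)Nc3ccc(C(=O)O)cc3)nc2-c2cc(OC)c(OC)c(OC)c2)cc1` is not yet measured. Its difference from compound 3 is 4-carboxyphenyl in place of 2-methylphenyl on an amide-type nitrogen. The two steps that bear on it, 1>3 and 2>3, show that exchanging the group on the amide-type nitrogen can move the read-out by a modest to large amount, and that the two aryl groups already seen differ from each other. Going by the values given here, no step with a carboxy group exists, so the direction is open. Compound 4 is expected to sit between the aryl values, with an estimated step of a number 6 percentage points higher from compound 3 to compound 4 (within the scatter) that need not exceed the scatter. The estimate for compound 4 is 80%, within 50% to 105%.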

Compound 4, a percentage reported as inhibition, in the whole organism at one dose (the size of the read-out at that dose, not a potency): 109%
The estimate for compound 4 lay 29 percentage points below the measured number, outside the stated range (above it).
By their numbers in this assay, from the lowest: compound 3; then compounds 2, 1 and 4 (each within the scatter of the next).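

In this assay, 4-carboxyphenyl on the amide-type nitrogen brings a number 35 percentage points higher from compound 3 to compound 4 (beyond the scatter), so an aryl group at this position need not carry the cost seen with 2-methylphenyl. The position also accepts a carboxy group on that aryl ring: the exchange for methoxy reads a number 10 percentage points higher from compound 2 to compound 4 (within the scatter), and the exchange of the whole group for methyl reads no change at the digits printed from compound 1 to compound 4 (within the scatter). Among the four compounds, only the 2-methylphenyl of compound 3 stands apart, and nothing measured here accounts for this.

The compounds shown do not separate the effect of the methyl group from that of its place on the ring, which 4-methylphenyl or 2-carboxyphenyl on the same nitrogen would address. On these data alone, how an amine such as 4-aminophenyl, or a longer chain such as butyl, would read at this position also remains open.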